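Ring-fused amine substituent replacing pyrrolidinyl in caspase-8 inhibitors

The source may hold more compounds than are shown below. What is called first, only, known or untested is meant among the compounds shown, and "the series" means these compounds.

Measured compounds:
Compound 1 `CCCCCCN(C)CNCC(=O)[C@H](CC(=O)O)NC(=O)C(CC)n1cc(CC)nc(NCc2nonc2C)c1=O` gives 9540 nM in an assay for inhibition of Caspase-8 (Homo sapiens); a lower number here means a stronger inhibitor, a higher number a weaker inhibitor.
Compound 2 `CCC(C(=O)N[C@@H](CC(=O)O)C(=O)CNCN1CCc2ccccc2C1)n1ccnc(NCc2nonc2C)c1=O` gives 7380 nM in this assay.
Compound 3 `CCC(C(=O)N[C@@H](CC(=O)O)C(=O)CNCN1CCCC1)n1ccnc(NCc2nonc2C)c1=O` gives 6220 nM in this assay.

Compound 3 has the lowest of the three numbers, but its gaps to compound 2 and to compound 1 both fall within the scatter, so no order among them can be stated. Compound 4 `CCC(C(=O)N[C@@H](CC(=O)O)C(=O)CNCN1Cc2ccccc2C1)n1ccnc(NCc2nonc2C)c1=O` differs from compound 3 by a group of 9 heavy atoms (8 carbon, 1 nitrogen; one five-membered non-aromatic ring with 1 hetero atom, one six-membered aromatic ring of carbon only) in place of a group of 5 heavy atoms (4 carbon, 1 nitrogen; one five-membered non-aromatic ring with 1 hetero atom), on a saturated chain carbon bound to an amine nitrogen.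

Going by the values given here, the only step that bears on this change is a 1.2-fold lower number from compound 2 to compound 3 (0.07 log units; within the scatter), where a different ring-fused amine stood on the same saturated chain carbon and no movement beyond the scatter appeared. Compound 4 is therefore expected to show no step beyond the scatter, estimated as a 1.0-fold higher number from compound 3 to compound 4 (0.02 log units; within the scatter). Compound 4 is expected to give about 6500 nM in this assay, within a range of 3000 nM to 14000 nM.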

Compound 4, half-maximal inhibitory concentration: 4290 nM
Compound 4: middle estimate off by 1.5-fold (0.18 log units), on the high side; measured number inside the range.
By their numbers in this assay, from the lowest: compounds 4, 3, 2 and 1 (each within the scatter of the next, the first and the last beyond it).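

At this saturated chain carbon bound to an amine nitrogen, adding a six-membered aromatic ring of carbon only to the five-membered ring produces no movement beyond the scatter in this assay, with a 1.4-fold lower number from compound 3 to compound 4 (0.16 log units; within the scatter). Changing the non-aromatic ring of the ring-fused amine from six-membered to five-membered does not do so either, with a 1.7-fold lower number from compound 2 to compound 4 (0.24 log units; within the scatter). No outside information bears on these small differences.

From the compounds shown here alone, it remains open whether morpholin-4-yl or piperidin-1-yl on this carbon would give a step beyond the scatter. The same question stands for a carboxylic acid on the six-membered aromatic ring.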